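A few compounds are considered here, and "the series" means these few. Any claim that something is new, unique, unknown or untested is made for them only; others in the source may bear on it.

Compound 1 `COc1cc(-c2cc(/C=C/C(=O)c3ccc(Cl)c(Cl)c3)[nH]n2)cc(OC)c1OC` was tested in a functional assay on HCC 2998 cells (Homo sapiens) for cytotoxicity, read by sulforhodamine B assay, with a stated time of 48 h, tested at 100 uM (a higher number here means a weaker effect of the compound at the concentration tested, a lower number a stronger effect), where compound 1 gives -50%. That is the higher of the two numbers recorded so far; compound 2 `COc1ccc(-c2cc(/C=C/C(=O)c3cc(OC)c(OC)c(OC)c3)[nH]n2)cc1OC` gives -82% in this assay, a number beyond the scatter lower than that of compound 1. Compound 3 `COc1cc(-c2cc(/C=C/C(=O)c3ccc(F)c(F)c3)[nH]n2)cc(OC)c1OC` has not been measured. It differs from compound 1 by 3,4-difluorophenyl in place of 3,4-dichlorophenyl on a carbonyl carbon. Among the measured compounds shown here, with no measured pair showing this change, only a small shift toward a higher number, not clearly beyond the scatter, is expected: a number 10 percentage points higher from compound 1 to compound 3 (within the scatter). Compound 3 is therefore estimated at -40%, within -75% to 5%.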

Compound 3, a percentage reported as activity, at one concentration (the size of the read-out at that concentration, not a potency): -11%
Compound 3: middle estimate off by 29 percentage points, on the low side, and the stated range covers the measured number.
By their numbers in this assay, from the lowest: compound 2; then compound 1; then compound 3.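

With the aryl group on a carbonyl carbon, the halogen itself matters in this assay: 3,4-difluorophenyl in place of 3,4-dichlorophenyl gives a number 39 percentage points higher from compound 1 to compound 3 (beyond the scatter) and leaves a much weaker effect at the concentration tested. The two groups have the same count of heavy atoms and the same ring, so this position distinguishes between groups that match on those counts. Nothing measured here explains the step. The compounds shown leave open how 3,4-dibromophenyl, or a phenyl ring carrying a trifluoromethyl group or an amine, would behave at this carbonyl carbon.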